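Adding a Methyl to the Pyrazole: Lipophilicity Outlook

The compounds below may be only part of what the source reports. "The series", "measured", "known", "first", "only" and "open" are said of these compounds alone.

Measured compounds:
compound 1, `CNC(=O)c1cc(-c2cnc(NCc3c(F)ccc4c3CCO4)c3cn[nH]c(=O)c23)n(C)n1`, 2.1;
compound 2, `CNC(=O)c1ccc(-c2cnc(NCc3c(F)ccc4c3CCO4)c3cn[nH]c(=O)c23)c(C)n1`, 2.9;
compound 3, `Cn1nccc1-c1cnc(NCc2c(F)ccc3c2CCO3)c2cn[nH]c(=O)c12`, 2.6.

Three compounds share one core and differ only in the aromatic group attached to it. In a physicochemical assay for lipophilicity, using the shake flask method, in phosphate buffer, measured as octanol-water partition, with a stated time of 30 min, at pH 7.4 (a higher number here means a more lipophilic compound, a lower number a more polar compound), compound 1 gives 2.1, compound 2 gives 2.9 and compound 3 gives 2.6. Compound 3 thus stands second highest of the three: its number sits within the scatter of compound 2, while compound 1 lies clearly lower, as a number 0.50 log units higher from compound 1 to compound 3 (beyond the scatter) shows.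

Compound 4, `Cc1nn(C)cc1-c1cnc(NCc2c(F)ccc3c2CCO3)c2cn[nH]c(=O)c12`, has not yet been measured in this assay. Its change from compound 3 is 1,3-dimethyl-1H-pyrazol-4-yl in place of 1-methyl-1H-pyrazol-5-yl on an aromatic carbon. For the measured compounds named here, none of the measured steps repeats this change exactly: a number 0.80 log units higher from compound 1 to compound 2 (beyond the scatter) and a number 0.30 log units lower from compound 2 to compound 3 (within the scatter) both swap whole aromatic groups, whereas here one methyl is added to the same kind of ring. Such a small addition of carbon is expected to move the number up only a little, by about a number 0.30 log units higher from compound 3 to compound 4 (within the scatter), a step close to the scatter.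

Compound 4 is therefore estimated at 2.9, with a likely range from 2.5 to 3.3.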

Compound 4, distribution coefficient: 2.8
The estimate for compound 4 lay 0.10 log units above the measured number; low and high end bracket the measured number.
By their numbers in this assay, from the lowest: compound 1; then compounds 3, 4 and 2 (each within the scatter of the next).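

In this assay, the group 1,3-dimethyl-1H-pyrazol-4-yl gives a number 0.20 log units higher from compound 3 to compound 4 (within the scatter), so on this aromatic carbon, para to a large group, this exchange of one methylpyrazole group for another stays inside the usual noise. The same group gives a number 0.10 log units lower from compound 2 to compound 4 (within the scatter) and a number 0.70 log units higher from compound 1 to compound 4 (beyond the scatter), so compound 4 sets compound 1 further apart while it cannot be told from compound 2, even though compound 2 keeps a methylcarbamoyl group as compound 1 does. No outside data on these groups are available to explain these numbers. The compounds shown leave open how much of the step from compound 3 belongs to the added methyl and how much to the shift from 5-yl to 4-yl, which a 1-methyl-1H-pyrazol-4-yl group would separate. Going by these compounds, how an amine or a carboxylic acid on the pyrazole would move the number also remains open.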